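Methyl to bromo in an antiproliferative pair

A few compounds are considered here, and "the series" means these few. Any claim that something is new, unique, unknown or untested is made for them only; others in the source may bear on it.

In a functional assay on MCF7 cells (Homo sapiens) for antiproliferative activity, read by MTT assay, with a stated time of 48 h (a higher number here means a weaker inhibitor, a lower number a stronger inhibitor), compound 1 (`Cc1ccc(S(=O)(=O)NC(=O)c2cccnc2)cc1`) gives 12000 nM and compound 2 (`Cc1ccc(S(=O)(=O)NC(=O)c2ccc(Cl)nc2)cc1`) gives 17200 nM as its reading. For the measured compounds named here, these two values lie within the scatter of each other, so compound 2 stands level with the only other measured compound and the two cannot be ranked. The unmeasured compound 3 (`O=C(NS(=O)(=O)c1ccc(Br)cc1)c1ccc(Cl)nc1`) differs from compound 2 by a single exchange (bromo in place of methyl on an aromatic carbon) of bromo in place of methyl on an aromatic carbon. Going by the values given here, only one measured step bears on this, and only loosely: a 1.4-fold higher number from compound 1 to compound 2 (0.16 log units; within the scatter) for chloro in place of hydrogen on an aromatic carbon, which stays within the scatter. Among the compounds with values here, that step lies at a different place in the structure, and no measured compound carries bromo, so the data offer no direct guide. A step beyond the scatter is therefore not expected in this assay in either direction. The estimate means a 1.1-fold lower number from compound 2 to compound 3 (0.06 log units; within the scatter) as the expected step. Compound 3 is expected at 15000 nM with an estimated range from 6000 nM to 40000 nM for its reading.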

Compound 3, half-maximal inhibitory concentration: 9050 nM
Compound 3: the middle estimate sits 1.7-fold (0.22 log units) above what was measured, within the range that was stated.
By their numbers in this assay, from the lowest: compounds 3, 1 and 2 (each within the scatter of the next).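

In this assay, bromo in place of methyl on an aromatic carbon, para to a large group, gives a 1.9-fold lower number from compound 2 to compound 3 (0.28 log units; within the scatter), and this is the only reading shown for a change at this position, as the earlier step with chloro lay at a different place in the structure. The position therefore accepts a single heavy halogen atom in place of a single carbon, with no step beyond the scatter and no separation of compound 3 from compound 2, so the exchange neither gains nor loses anything that can be read in this assay. Nothing measured here explains the size of this step, and no supporting data bear on it.

What the compounds shown leave open is whether a quite different group on this aromatic carbon, such as an amine or a carboxylic acid, would give a step beyond the scatter. As far as these compounds go, it also remains open whether bromo would give a similar step on the core of compound 1, which carries hydrogen where compound 2 carries chloro.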